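Replacing ethoxy with 4-methylphenyl in compound 3

The compounds below may be only part of what the source reports. "The series", "measured", "known", "first", "only" and "open" are said of these compounds alone.

For the measured compounds named here, in a functional assay on KB cells (Homo sapiens) for cytotoxicity (on this read-out higher numbers stand for weaker inhibition and lower numbers for stronger inhibition), compound 3 (`CCOCn1cc(C(=N)S)c2c(N)ncnc21`) gives 68000 nM as the only true number so far. Compound 2 (`CCOCn1cc(C(N)=O)c2c(N)ncnc21`) gives > 100000 nM as a limit of the assay. Compound 1 (`Cc1ccc(Cn2cc(C#N)c3c(N)ncnc32)cc1`), which already carries 4-methylphenyl, gives > 100000 nM as a limit of the assay too. Compound 4 (`Cc1ccc(Cn2cc(C(=N)S)c3c(N)ncnc32)cc1`) differs from compound 3 by one change (4-methylphenyl in place of ethoxy on a saturated chain carbon bound to an aromatic nitrogen), namely 4-methylphenyl in place of ethoxy on a saturated chain carbon bound to an aromatic nitrogen. Going by the values given here, no measured step makes this change. Among the compounds with values here, the only measured step (an at least 1.4-fold lower number from compound 2 to compound 3 (0.16 log units; that floor lies within the scatter)) alters another group and stays within the scatter. Taking compound 3 at 68000 nM as the anchor, no step beyond the scatter is expected in this assay (a 1.5-fold lower number from compound 3 to compound 4 (0.18 log units; within the scatter)). For compound 4 the estimated value is 45000 nM (range 10000 nM to 100000 nM).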

Compound 4, half-maximal inhibitory concentration: 65000 nM
Estimate against measurement, compound 4: 1.4-fold (0.16 log units) below; the range from low to high includes it.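

In this assay, the change of 4-methylphenyl in place of ethoxy on a saturated chain carbon bound to an aromatic nitrogen can now be read directly, as a 1.0-fold lower number from compound 3 to compound 4 (0.02 log units; within the scatter), so these two groups do not separate at this position. With 4-methylphenyl in place, the change on the aromatic carbon gives an at least 1.5-fold lower number from compound 1 to compound 4 (0.18 log units; that floor lies within the scatter). That step can be read only as a floor because it starts from a limit: the limit of > 100000 nM in this assay, at which 2 of the 4 values shown sit.

On these data alone, whether an amine, a carboxylic acid or a longer chain at this position would give a step beyond the scatter stays open. No step shown so far in this assay is printed as beyond the scatter, so neither position has yet been shown to shift the number.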